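Isopropyl in Place of Methyl on the Phenol Ring

The compounds below may be only part of what the source reports. "The series", "measured", "known", "first", "only" and "open" are said of these compounds alone.

Compound 1, `O=C(O)CCCSCCN1C(=O)CCC[C@@H]1/C=C/C(O)C1(c2ccccc2)CC1`, gives in a functional assay with prostaglandin E2 receptor EP4 subtype (Homo sapiens) as the target (a higher number here means that more compound is needed for the effect, a lower number that less compound is needed), a value of 260 nM.
Compound 2, `COCc1cccc(C[C@H](O)/C=C/[C@H]2CCCC(=O)N2CCCCCCC(=O)O)c1`, gives in this assay a value of 44 nM.
Compound 3, `Cc1cc(C[C@H](O)/C=C/[C@H]2CCCC(=O)N2CCCCCCC(=O)O)ccc1O`, gives in this assay a value of 280 nM.

Among these three numbers compound 3 stands at the top, though its gap to compound 1 lies within the scatter, so the two cannot be ordered. Among the compounds with values here, its distance to compound 2 is another matter: the one step that the measured set provides, a 6.4-fold higher number from compound 2 to compound 3 (0.80 log units; beyond the scatter), swaps the whole aryl group and is beyond the scatter.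

Compound 4, `CC(C)c1cc(C[C@H](O)/C=C/[C@H]2CCCC(=O)N2CCCCCCC(=O)O)ccc1O`, differs from compound 3 by a smaller edit: isopropyl in place of methyl on an aromatic carbon. Within the data shown here, no measured pair isolates this exchange. The step from compound 2 to compound 3 alters the aryl group as a whole and says nothing about how a larger alkyl group next to the hydroxy group is tolerated. Among the measured compounds shown here, with no step to lean on, the account expects the change to stay within the scatter of this assay. Compound 4 is therefore estimated at 220 nM, with a range from 70 nM to 700 nM, which corresponds to an expected step of a 1.3-fold lower number from compound 3 to compound 4 (0.10 log units; within the scatter).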

Compound 4, half-maximal effective concentration: 1730 nM
Compound 4: the middle estimate sits 7.9-fold (0.90 log units) below what was measured; measured number outside the range, above it.
By their numbers in this assay, from the lowest: compound 2; then compounds 1 and 3 (each within the scatter of the next); then compound 4.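

In this assay the phenol ring proves sensitive at the position ortho to the hydroxy group: going from methyl, with 1 heavy atom, to isopropyl, with 3 heavy atoms, gives a 6.2-fold higher number from compound 3 to compound 4 (0.79 log units; beyond the scatter) and so lies beyond the scatter. This single alkyl exchange moves the number about as far as the replacement of the entire aryl group in a 6.4-fold higher number from compound 2 to compound 3 (0.80 log units; beyond the scatter), which the earlier compounds could not have shown. The two changes together appear in a 39-fold higher number from compound 2 to compound 4 (1.59 log units; beyond the scatter), a large step that places the 4-hydroxy-3-isopropylphenyl group well behind the 3-(methoxymethyl)phenyl group on this chain and shows that the hydroxy-bearing ring does not tolerate every alkyl group equally.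

Nothing shown here gives a reason for this rise in the number. With only methyl and isopropyl at this position, the compounds leave open whether ethyl or tert-butyl would fall on the same trend, and whether a chlorine atom or a methoxy group there would behave like either alkyl group.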